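The source may report more compounds than this note shows. Statements on the series, on what has been measured and on what is new or still open speak of the compounds shown alone.

Measured so far in a functional assay (mitochondria) for inhibition, with Rattus norvegicus as the target; a higher number here means a weaker inhibitor, a lower number a stronger inhibitor:
- compound 1 (`Cc1nc2cc(OC[C@H](O)CN3CCN(CC(=O)Nc4c(C)cccc4C)C[C@@H]3C)ccc2s1`) gives 200 nM
- compound 2 (`Cc1nc2cc(OCC(O)CN3CCN(CC(=O)Nc4c(C)cccc4C)CC3(C)C)ccc2s1`) gives 450 nM

Of these two, compound 1 has the lower number and so is the stronger inhibitor in this assay. Compound 2, at 450 nM, sits higher, and the gap between them lies beyond the usual scatter.

The next compound to be tested is compound 3 (`Cc1nc2cc(OC[C@H](O)CN3CCN(CC(=O)Nc4c(C)cccc4C)C[C@H]3C)ccc2s1`), the counterpart of compound 1 with the same atoms and bonds. The comparison is the two compounds have the same atoms and bonds and differ only in configuration as drawn: 1 of 2 stereo elements differ; a stereocentre at a saturated ring carbon is drawn S in compound 1 and R in compound 3, so a stereocentre at a saturated ring carbon is drawn S in compound 1 and R in compound 3. Among the compounds with values here, no measured pair here isolates such a change, so the data give no direct guide to its size. A modest move toward a higher number is expected, possibly not much beyond the scatter, and a weaker compound 3 is thought more likely than a stronger one. The estimate is a 1.5-fold higher number from compound 1 to compound 3 (0.18 log units; within the scatter) as the expected step. For compound 3 the estimated value is 300 nM, with an expected range from 110 nM to 800 nM in this measurement.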

Compound 3, half-maximal inhibitory concentration: 2000 nM
Compound 3: the middle estimate sits 6.7-fold (0.82 log units) below what was measured, outside the stated range (above it).
By their numbers in this assay, from the lowest: compound 1; then compound 2; then compound 3.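

In this assay, the configuration at this saturated ring carbon matters a great deal: changing it from S to R gives a 10-fold higher number from compound 1 to compound 3 (1.00 log units; beyond the scatter), a step well beyond the scatter. Within the data shown here, the earlier compounds held no pair that isolated a change of this kind, so this is the first direct reading of the position, and of the two forms the one drawn S in compound 1 is the stronger inhibitor. The whole step can be assigned to this one stereocentre, because nothing else separates the pair: the fact that compounds 1 and 3 differ only in the configuration as drawn

From the compounds shown here alone, the other stereo element is drawn the same way in both compounds, so its own contribution remains open, as does whether the preference for S would hold if it were inverted. Among these compounds, also open is how an ethyl or a hydroxymethyl group in place of the methyl at this stereocentre would read in this assay, and the pair shows only that configuration here changes the number, not the mechanism behind that change.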